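Fluoro Scan on Pyrazole Carboxamide Benzothiazoles

The source may report more compounds than this note shows. Statements on the series, on what has been measured and on what is new or still open speak of the compounds shown alone.

Measured compounds:
- compound 1 `COc1ccc2nc(NC(=O)c3cn(-c4ccccc4)nc3-c3ccccc3)sc2c1`: > 50000 nM in a functional assay on HT-29 cells (Homo sapiens) for cytotoxicity, read by MTT assay, with a stated time of 72 h (on this read-out lower numbers stand for stronger inhibition and higher numbers for weaker inhibition), a limit of the assay
- compound 2 `COc1ccc2nc(NC(=O)c3cn(-c4ccccc4)nc3-c3ccc(F)cc3)sc2c1`: 33200 nM
- compound 3 `COc1ccc(-c2nn(-c3ccccc3)cc2C(=O)Nc2nc3ccccc3s2)cc1`: 10500 nM

Compound 1 reaches only the assay limit, (the limit of > 50000 nM in this assay, at which 1 of the 3 values shown sits). Compound 2 differs from compound 1 by fluoro in place of hydrogen on an aromatic carbon, and the step is an at least 1.5-fold lower number from compound 1 to compound 2 (0.17 log units; that floor lies within the scatter). Compound 3 carries the same atoms as compound 1 joined differently; the difference between the two cores is not broken down here. Compound 3 stands at the lowest number of the two that are real numbers, with compound 2 next.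

Compound 4 `COc1ccc(-c2nn(-c3ccccc3)cc2C(=O)Nc2nc3ccc(F)cc3s2)cc1` is not yet measured. It differs from compound 3 by fluoro in place of hydrogen on an aromatic carbon. This is the same kind of change as that from compound 1 to compound 2, not the same: there the fluoro entered on a six-membered aromatic ring of carbon only, para to a large group; here it enters on a six-membered aromatic ring of carbon only that is part of a fused or bridged system of two rings, meta to a fused ring and para to a fused ring.

Among the compounds with values here, the one measured example of this kind of change gives only a weak precedent. The expectation for compound 4 therefore rests on that precedent and on compound 3 at 10500 nM. The step from compound 3 to compound 4 is expected to be a 1.4-fold lower number from compound 3 to compound 4 (0.15 log units; within the scatter), of the order seen from compound 1 to compound 2. Compound 4 is therefore estimated at 7500 nM, with a plausible range from 2500 nM to 25000 nM.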

Compound 4, half-maximal inhibitory concentration: 5560 nM
Compound 4: the middle estimate sits 1.3-fold (0.13 log units) above what was measured, and the stated range covers the measured number.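

In this assay, going from 1,3-benzothiazol-2-yl to 6-fluoro-1,3-benzothiazol-2-yl gives a 1.9-fold lower number from compound 3 to compound 4 (0.28 log units; within the scatter), so this step on its own cannot be told apart from repeat measurement. Set beside the earlier case of the same change on the other core, the comparison reads: the same change on two cores in this assay, an at least 1.5-fold lower number (0.17 log units; that floor lies within the scatter) from compound 1 to compound 2 and a 1.9-fold lower number (0.28 log units; within the scatter) from compound 3 to compound 4; the limit leaves it open whether they differ. Both steps point the same way on their face, but neither is beyond the scatter and the fluoro stands in a different setting on each core, so the notes support no claim that a gain carries from one core to the other, and equally none that the two cores respond differently.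

Still open, on these data alone, is how the same fluoro would behave at the other site on a single core, since a matched pair of that kind would separate the effect of the core from the effect of the place. Also open, as far as these compounds go, is whether a different group at the place taken by fluoro in compound 4, such as chloro, an amine or a carboxylic acid, would give a step that clears the scatter in this assay.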